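The source may hold more compounds than are shown below. What is called first, only, known or untested is meant among the compounds shown, and "the series" means these compounds.

Measured in a functional assay on HepG2 cells (Homo sapiens) for antiproliferative activity, read by MTT assay, with a stated time of 72 h; on this read-out higher numbers stand for weaker inhibition and lower numbers for stronger inhibition:

Compound 1 (`CCN(CC)CCCOc1cc2ncnc(Nc3ccc(C#N)cc3)c2cc1OC`): 59400 nM
Compound 2 (`COc1cc2c(Nc3ccc(C#N)cc3)ncnc2cc1OCCCN(C)Cc1ccccc1`): > 100000 nM (a limit of the assay, not a number)
Compound 3 (`COc1cc2c(Nc3ccc(C#N)cc3)ncnc2cc1OCCCN1CCC(C)CC1`): 32100 nM

Only compound 1 and compound 3 have actual numbers, and these lie within the scatter of each other (a 1.9-fold lower number from compound 1 to compound 3 (0.27 log units; within the scatter)). Compound 2 has only its limit, so steps involving it are minimum sizes. One such step stays within the scatter (an at least 1.6-fold higher number from compound 1 to compound 2 (0.22 log units; that floor lies within the scatter)), while another goes beyond it (an at least 3.1-fold lower number from compound 2 to compound 3 (0.49 log units; beyond the scatter)).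

Compound 4 (`COc1cc2c(Nc3ccc(C#N)cc3)ncnc2cc1OCCCN1CCC(O)CC1`) differs from compound 3 in one place: hydroxy in place of methyl on a saturated ring carbon. Going by the values given here, no measured step makes this exact exchange. Among the compounds with values here, the closest guides are the three swaps of the whole group at the end of the chain, and only the one involving compound 2 clearly shows a change. Compound 3 keeps its ring here, so no step beyond the scatter is expected in this assay, with at most a slight drift towards a higher number. The expected change is small (a 1.4-fold higher number from compound 3 to compound 4 (0.15 log units; within the scatter)). For compound 4 the estimated value is 45000 nM with an expected range from 18000 nM to 100000 nM in this measurement.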

Compound 4, half-maximal inhibitory concentration: 67900 nM
For compound 4 the middle estimate is 1.5-fold (0.18 log units) below the measured one, and the stated range covers the measured number.
By their numbers in this assay, from the lowest: compounds 3, 1 and 4 (each within the scatter of the next, the first and the last beyond it). At a limit, above all of these: compound 2.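

In this assay, going by these compounds alone, the earlier steps swapped the whole group at the end of the chain, whereas this exchange keeps the ring and replaces methyl with hydroxy on a saturated ring carbon, three ring bonds from the ring nitrogen. Even this one-atom exchange, which adds a hydrogen-bond donor and a hydrogen-bond acceptor by count, gives a 2.1-fold higher number from compound 3 to compound 4 (0.33 log units; beyond the scatter) and so registers as a modest step at this position. The 4-hydroxypiperidin-1-yl end group is still not separated from diethylamino, with a 1.1-fold higher number from compound 1 to compound 4 (0.06 log units; within the scatter) as the step between them, and compound 2 has only a limit, so an at least 1.4-fold lower number from compound 2 to compound 4 (0.16 log units; that floor lies within the scatter) is a minimum and leaves the size of that step unknown: the limit of > 100000 nM in this assay, at which 1 of the 4 values shown sits.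

Methyl and hydroxy are the only groups seen on this ring carbon, so it remains open whether an amine, a methoxy group, a fluorine atom or a carboxylic acid there would move the number in the same direction. Going by these compounds, it is also open whether the same exchange would give a similar step on a longer chain.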